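Swapping 3-chlorophenyl for 4-fluorophenyl on a shared core

The compounds below may be only part of what the source reports. "The series", "measured", "known", "first", "only" and "open" are said of these compounds alone.

Of the compounds shown here, three with one shared core have numbers so far. In a functional assay on MDA-MB-435 cells (Homo sapiens) for antiproliferative activity, read by sulforhodamine B assay, with a stated time of 48 h (a lower number here means a stronger inhibitor, a higher number a weaker inhibitor), compound 1 `COc1ccc(-c2nsc3c2NC(=O)CC3c2ccc3c(c2)OCCO3)cc1` gives 247 nM and compound 2 `COc1ccc(-c2nsc3c2NC(=O)CC3c2cccc(Cl)c2)cc1` gives 749 nM while compound 3 `COc1ccc(-c2nsc3c2NC(=O)CC3c2cccc(F)c2)cc1` gives 827 nM on the same scale. Compound 2 therefore stands level with compound 3, and the number for compound 1 is clearly lower than both.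

Compound 4 `COc1ccc(-c2nsc3c2NC(=O)CC3c2ccc(F)cc2)cc1` has no number yet. It carries 4-fluorophenyl in place of the 3-chlorophenyl of compound 2 on a saturated ring carbon, a swap summed up as 4-fluorophenyl in place of 3-chlorophenyl on a saturated ring carbon in full.

Within the data shown here, the one measured step that bears on this, a 1.1-fold higher number from compound 2 to compound 3 (0.04 log units; within the scatter) for fluoro in place of chloro on an aromatic carbon, is small. Among the measured compounds shown here, no measured step shows what a shift of the halogen around the ring does, so the range stays wide. In this assay no change beyond the scatter is expected, in either direction. The estimated change is a 1.1-fold higher number from compound 2 to compound 4 (0.03 log units; within the scatter) for this swap. For compound 4 the expected value is 800 nM within an estimated range from 350 nM to 1800 nM in repeated measurements.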

Compound 4, half-maximal inhibitory concentration: 440 nM
Compound 4: the middle estimate sits 1.8-fold (0.26 log units) above what was measured; the range from low to high includes it.
By their numbers in this assay, from the lowest: compounds 1, 4, 2 and 3 (each within the scatter of the next, the first and the last beyond it).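

In this assay, putting 4-fluorophenyl on the saturated ring carbon in place of 3-chlorophenyl gives one step (a 1.7-fold lower number from compound 2 to compound 4 (0.23 log units; within the scatter)), and putting it in place of 3-fluorophenyl gives another (a 1.9-fold lower number from compound 3 to compound 4 (0.27 log units; within the scatter)). Among these compounds, the second step is the first direct look at moving a halogen around this phenyl ring, and together the steps show that neither the move nor the swap of halogen with it leaves the scatter for these three compounds. Nothing measured here accounts for these numbers.

Going by these compounds, it stays open whether 4-chlorophenyl at this carbon would give a number close to those of these three compounds. Also open, on these data alone, is what an amine or a carboxylic acid on this phenyl ring would do to the number.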